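Carboxy in place of methoxycarbonyl on the pyridyl of compound 3

This account rests on a few compounds, and the source may have more. Where it says the series, first, only, none or still open, it means among the compounds named here.

compound 1 `COC(=O)c1ccc(-c2cnc(C(O)CCc3ccc(-c4ccccc4)cc3)o2)nc1`: 1100 nM
compound 2 `O=C(O)c1cccc(-c2cnc(C(O)CCc3ccc(-c4ccccc4)cc3)o2)n1`: 1100 nM
compound 3 `COC(=O)c1cccc(-c2cnc(C(O)CCc3ccc(-c4ccccc4)cc3)o2)n1`: 9000 nM

In an assay for inhibition of Fatty-acid amide hydrolase 1 (Rattus norvegicus) (a lower number here means a stronger inhibitor, a higher number a weaker inhibitor), compound 3 gives the highest of the three numbers, and compound 1 and compound 2 lie an equal distance below it, as the steps of an 8.2-fold higher number from compound 1 to compound 3 (0.91 log units; beyond the scatter) and an 8.2-fold higher number from compound 2 to compound 3 (0.91 log units; beyond the scatter) show. Compound 4 `O=C(O)c1ccc(-c2cnc(C(O)CCc3ccc(-c4ccccc4)cc3)o2)nc1` differs from compound 3 by 5-carboxypyridin-2-yl in place of 6-(methoxycarbonyl)pyridin-2-yl on an aromatic carbon. Going by the values given here, two measured steps bear on this change, each run in reverse: the step of an 8.2-fold higher number from compound 1 to compound 3 (0.91 log units; beyond the scatter) and the step of an 8.2-fold higher number from compound 2 to compound 3 (0.91 log units; beyond the scatter). Undoing either one lowers the number. The step of no change at the digits printed from compound 1 to compound 2 (within the scatter) suggests that combining the two brings no further gain. Compound 4 is therefore expected to show a 13-fold lower number from compound 3 to compound 4 (1.11 log units; beyond the scatter) in this assay. The estimate for compound 4 is 700 nM, with a range from 150 nM to 3000 nM.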

Compound 4, inhibition constant: 10000 nM
Estimate against measurement, compound 4: 14-fold (1.15 log units) below; measured number outside the range, above it.
By their numbers in this assay, from the lowest: compounds 1 and 2 (each within the scatter of the next); then compounds 3 and 4 (each within the scatter of the next).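

In this assay, the ester methyl and the place of the group do not act independently: hydrogen in place of that methyl on the 5-substituted pyridyl gives a 9.1-fold higher number from compound 1 to compound 4 (0.96 log units; beyond the scatter). The same change on the 6-substituted pyridyl runs the other way, so its outcome depends on where the group sits: the same change on two cores in this assay, an 8.2-fold higher number (0.91 log units; beyond the scatter) from compound 2 to compound 3 and a 9.1-fold lower number (0.96 log units; beyond the scatter) from compound 4 to compound 1, 74-fold (1.87 log units) apart, beyond the scatter of two such steps. Moving the carboxy group gives a 9.1-fold higher number from compound 2 to compound 4 (0.96 log units; beyond the scatter), while a 1.1-fold higher number from compound 3 to compound 4 (0.05 log units; within the scatter) shows that 5-carboxypyridin-2-yl and 6-(methoxycarbonyl)pyridin-2-yl cannot be told apart here. On these data alone, whether an amide or a hydroxymethyl group in place of the carboxylic acid would show the same dependence on place stays open.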